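The compounds below may be only part of what the source reports. "The series", "measured", "known", "first", "only" and "open" are said of these compounds alone.

Measured in a functional assay on A-431 cells (Homo sapiens) for inhibition, read by MTT assay, with a stated time of 72 h; a lower number here means a stronger inhibitor, a higher number a weaker inhibitor:
- compound 1 `COc1ccc(-c2nnc(SCCCN3CCN(c4nc5ccccc5s4)CC3)o2)cc1`: 56200 nM
- compound 2 `CC(C)(C)Oc1ccc(-c2nnc(SCCCN3CCN(c4nc5ccccc5s4)CC3)o2)cc1`: 67000 nM

In this assay, compound 2 gives 67000 nM and stands level with compound 1 within the usual scatter. Compound 3 `O=C(NCc1nnc(SCCCN2CCN(c3nc4ccccc4s3)CC2)o1)c1ccccc1` keeps the shared core but exchanges a whole group, with benzamidomethyl in place of 4-(tert-butoxy)phenyl on an aromatic carbon. Among the compounds with values here, the only measured step is a 1.2-fold higher number from compound 1 to compound 2 (0.08 log units; within the scatter). That step alters only part of the group that leaves here, so it is weak evidence. Within the data shown here, no measured compound carries benzamidomethyl, so the direction stays open and no shift beyond the scatter is expected in this assay, though surprise remains possible. The expected change is a 1.1-fold lower number from compound 2 to compound 3 (0.05 log units; within the scatter). Compound 3 is estimated at 60000 nM, within an expected range of 25000 nM to 130000 nM.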

Compound 3, half-maximal inhibitory concentration: 55900 nM
The estimate for compound 3 lay 1.1-fold (0.03 log units) above the measured number, within the range that was stated.
By their numbers in this assay, from the lowest: compounds 3, 1 and 2 (each within the scatter of the next).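

In this assay the earlier pair changed only the group on the oxygen, whereas compound 3 exchanges the whole 4-(tert-butoxy)phenyl or 4-methoxyphenyl group on this aromatic carbon for benzamidomethyl, and the numbers still stay within the scatter (a 1.2-fold lower number from compound 2 to compound 3 (0.08 log units; within the scatter) and a 1.0-fold lower number from compound 1 to compound 3 (0.00 log units; within the scatter)). So a much larger change at this position, one that also brings in a hydrogen-bond donor and a double bond outside aromatic rings, leaves all three compounds level in this assay. No measurement shown here offers an explanation for this flat result. On these data alone, whether a different kind of group at this position, such as a carboxylic acid or a simple amine, would shift the number beyond the scatter stays open. Also open, as far as these compounds go, is whether a longer chain in the shared core would matter more than the group at this position.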